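This account rests on a few compounds, and the source may have more. Where it says the series, first, only, none or still open, it means among the compounds named here.

Compound 1 `Cn1c(-c2ccccc2)nc2c(NC3CCCC3)ncnc21` gives 8510 nM in a functional assay on CHO cells for antagonist activity at adenosine receptor A2b (Homo sapiens), read by 33P incorporation, with a stated time of 20 min; a higher number here means a weaker inhibitor, a lower number a stronger inhibitor.
Compound 2 `CCn1c(-c2ccccc2)nc2c(NC3CCCC3)ncnc21` gives 5790 nM.
Compound 3 `Cn1c(-c2ccccc2)nc2c(NC3CCC3)ncnc21` gives 3730 nM.

Among these three numbers, compound 2 stands second highest. Its nearest neighbour is compound 1, and the step of a 1.5-fold lower number from compound 1 to compound 2 (0.17 log units; within the scatter) shows that the two cannot be told apart. Compound 3 has the lowest number, and its distance from compound 2 is also within the scatter, so no order between compound 2 and compound 3 can be claimed. Within the data shown here, only the step of a 2.3-fold lower number from compound 1 to compound 3 (0.36 log units; beyond the scatter) reaches beyond the scatter, and it is modest.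

The unmeasured compound 4 `CCn1c(-c2ccccc2)nc2c(NC3CCOC3)ncnc21` differs from compound 2 in one place: oxolan-3-yl in place of cyclopentyl on a nitrogen on an aromatic ring. The change sits at the same place as the step from compound 1 to compound 3, which read cyclobutyl in place of cyclopentyl and gave a 2.3-fold lower number from compound 1 to compound 3 (0.36 log units; beyond the scatter); that step, however, kept a ring of carbon only, whereas here a ring with one hetero atom enters. The step of a 1.5-fold lower number from compound 1 to compound 2 (0.17 log units; within the scatter) touches a different place and says nothing about this ring. Among the measured compounds shown here, no measured step exchanges a ring carbon for an oxygen, so the expectation rests on the general observation that changes at this place have stayed modest: the step of a 1.1-fold higher number from compound 2 to compound 4 (0.05 log units; within the scatter) is expected to be small. Compound 4 is therefore estimated at 6500 nM, with a likely range from 2500 nM to 17000 nM.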

Compound 4, inhibition constant: 11500 nM
The estimate for compound 4 lay 1.8-fold (0.25 log units) below the measured number, within the range that was stated.
By their numbers in this assay, from the lowest: compounds 3, 2, 1 and 4 (each within the scatter of the next, the first and the last beyond it).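

In this assay, among these compounds, the step of a 2.0-fold higher number from compound 2 to compound 4 (0.30 log units; within the scatter) is the first reading at this position of a ring that is not carbon only. Oxolan-3-yl keeps the five-membered ring and the five heavy atoms of cyclopentyl, but one ring carbon becomes an oxygen and the group gains a hydrogen-bond acceptor, and this exchange still falls inside the scatter, so the two compounds cannot be told apart here and the assay shows no clear effect of that oxygen on this nitrogen-bound ring. The measurements give no explanation of this outcome, and no independent data on these compounds bear on it.

The compounds shown leave open whether a ring carrying a basic nitrogen, such as pyrrolidin-3-yl or piperidin-4-yl, or a cyclopentyl ring bearing a hydroxyl group, would also stay within the scatter at this place. They also leave open whether oxolan-3-yl reads the same way with methyl rather than ethyl on the aromatic nitrogen of the shared core, and whether the smaller oxetan-3-yl ring would follow cyclobutyl or oxolan-3-yl.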